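Swapping pyridin-4-yl for methyl when only limits are known

The source may hold more compounds than are shown below. What is called first, only, known or untested is meant among the compounds shown, and "the series" means these compounds.

Measured in an ADME assay on Vero cells (Chlorocebus sabaeus) for cytotoxicity, read by MTT assay, with a stated time of 48 h; a higher number here means a weaker inhibitor, a lower number a stronger inhibitor:
- Compound 1 `CS(=O)(=O)OC1CCC(CN2CCN(c3cc(=O)c4cc(C(F)(F)F)cc([N+](=O)[O-])c4s3)CC2)CC1`: a limit, > 64 ug/mL
- Compound 2 `O=c1cc(N2CCN(CC3CCC(NS(=O)(=O)c4ccccc4)CC3)CC2)sc2c([N+](=O)[O-])cc(C(F)(F)F)cc12`: a limit, > 64 ug/mL
- Compound 3 `O=C(OC1CCC(CN2CCN(c3cc(=O)c4cc(C(F)(F)F)cc([N+](=O)[O-])c4s3)CC2)CC1)c1ccncc1`: a limit, > 64 ug/mL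

Compound 3 has no exact number, only a limit, and it stands with the other two compounds: the limit of > 64 ug/mL in this assay, at which 3 of the 3 values shown sit.

Compound 4 `CC(=O)OC1CCC(CN2CCN(c3cc(=O)c4cc(C(F)(F)F)cc([N+](=O)[O-])c4s3)CC2)CC1` differs from compound 3 in one group: methyl in place of pyridin-4-yl on a carbonyl carbon. This puts methyl in place of pyridin-4-yl on a carbonyl carbon, turning ((pyridin-4-yl)carbonyl)oxy into acetoxy.

Among the measured compounds shown here, two measured steps bear on this change, as both alter the same group of compound 3: a step that the two limits leave unreadable from compound 1 to compound 3 and a step that the two limits leave unreadable from compound 2 to compound 3. Neither has a size that can be read, so they offer no sign of a real effect and no direction. In this assay, no shift beyond the usual scatter is expected, and the most likely result is another limit. The expected change is a step that the limit leaves unreadable from compound 3 to compound 4. For compound 4 the estimated value is 70 ug/mL, within an expected range of 32 ug/mL to 128 ug/mL.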

Compound 4, half-maximal inhibitory concentration: > 64 ug/mL
Compound 4: a limit, no number; the forecaster's own chance of this, stated with the estimate: 85%; the middle value is on the limit's open side.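

No step among compound 1, compound 2, compound 3 and compound 4 can be read, because each result is a limit and not a number: the limit of > 64 ug/mL in this assay, at which 4 of the 4 values shown sit.

The compounds shown leave open whether these groups differ at all in this assay, and at what concentration any of the four becomes toxic to the cells.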